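Adding a Methoxy to the Core of Compound 3

This account rests on a few compounds, and the source may have more. Where it says the series, first, only, none or still open, it means among the compounds named here.

Measured compounds:
compound 1 `COc1cc(CC(O)(COCc2ccccc2)COCc2ccccc2)nc(OC)n1` — > 100000 nM
compound 2 `COc1cc(CC(COCc2ccccc2)COCc2ccccc2)nc(OC)n1` — "not determined" (no result reported)
compound 3 `COc1cc(CC(O)COCc2ccccc2)nc(OC)n1` — > 100000 nM

In a functional assay on MIA PaCa-2 cells (Homo sapiens) for antiproliferative activity, read by MTT assay, with a stated time of 72 h (a higher number here means a weaker inhibitor, a lower number a stronger inhibitor), compound 1 reaches only the limit of the assay, > 100000 nM. For compound 2, this assay reports no result, "not determined" (no result reported). Compound 3 likewise sits at the limit of this assay, > 100000 nM. Compound 3 therefore stands nowhere that can be placed against the others: of the three entries, two are limits and one is missing, as the limit of > 100000 nM in this assay, at which 2 of the 3 values shown sit, records. Within the data shown here, the only step between measured compounds, a step that the two limits leave unreadable from compound 1 to compound 3, cannot be read, as both of its ends are limits.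

The unmeasured compound 4 `COc1nc(CC(O)COCc2ccccc2)c(OC)c(OC)n1` differs from compound 3 by methoxy in place of hydrogen on an aromatic carbon. Among the measured compounds shown here, no measured step gives a usable size, and both measured values in this assay sit at the limit, so nothing can be carried over to the new change. Compound 4 is therefore expected to remain at or near the limit, estimated at 150000 nM with a range from 50000 nM to 1000000 nM. The step that the limit leaves unreadable from compound 3 to compound 4 is expected to be no larger than the scatter, with a high chance that only a limit is reported.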

Compound 4, half-maximal inhibitory concentration: > 100000 nM
Compound 4 gave a limit, no number; the forecaster's own chance of this, stated with the estimate: 85%; the middle value is on the limit's open side.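

In this assay compound 3 and compound 4 each give only a limit, and the step between them cannot be read. The compounds shown leave open whether methoxy in place of hydrogen on an aromatic carbon changes the result in this assay at all.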